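From Methyl to Butyl in a Potent Antiproliferative Series

A few compounds are considered here, and "the series" means these few. Any claim that something is new, unique, unknown or untested is made for them only; others in the source may bear on it.

Within the data shown here, in a functional assay on MDA-MB-231 cells (Homo sapiens) for antiproliferative activity, with a stated time of 4 days (a lower number here means a stronger inhibitor, a higher number a weaker inhibitor), compound 2 (`Cc1ccc(-c2[nH]c3ccc(C)cc3c2C=O)cc1`) gives 48 nM, the higher of the two numbers so far. Compound 3 (`CCCCc1ccc2[nH]c(-c3ccc(C)cc3)c(C=O)c2c1`) changes it in one place: propyl in place of hydrogen on a saturated chain carbon bound to an aromatic carbon, so methyl becomes butyl. Among the measured compounds shown here, no measured pair isolates this change. A butyl chain does appear in compound 1 (`CCCCc1ccc2[nH]c(-c3ccc(OC)cc3)c(C=O)c2c1`), which gives 6.7 nM, although another group differs there too. The expected step of a 4.0-fold lower number from compound 2 to compound 3 (0.60 log units; beyond the scatter) is a fall beyond the scatter, towards stronger inhibition. Compound 3 is estimated at 12 nM, with a range of 4 nM to 35 nM.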

Compound 3, half-maximal inhibitory concentration: 34 nM
The estimate for compound 3 lay 2.8-fold (0.45 log units) below the measured number; low and high end bracket the measured number.
By their numbers in this assay, from the lowest: compound 1; then compounds 3 and 2 (each within the scatter of the next).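

In this assay lengthening methyl to butyl gives a 1.4-fold lower number from compound 2 to compound 3 (0.15 log units; within the scatter) and so, for this pair, the longer chain makes no clear difference. Among these compounds, with butyl held fixed, methyl in place of methoxy on an aromatic carbon gives a 5.1-fold higher number from compound 1 to compound 3 (0.71 log units; beyond the scatter) and this is the one change here that moves the number beyond the scatter. Nothing available explains either step.

Open, going by these compounds, is whether a longer chain such as hexyl, or an amine at the chain end, would shift the number. Also open, on these data alone, is whether methoxy gives a similar step when the chain is methyl.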